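Swapping benzylamino for isopropylsulfanyl on a shared core

The source may report more compounds than this note shows. Statements on the series, on what has been measured and on what is new or still open speak of the compounds shown alone.

Compound 1, `CCCOc1nc(N)nc2c1ncn2/C=C1/CC1(CO)CO`, in an ADME assay on HFF cells (Homo sapiens) for cytotoxicity, with a stated time of 8 days (a higher number here means that more compound is tolerated, a lower number that less compound is tolerated), gives > 300000 nM, which is a limit of the assay and not a number.
Compound 2, `Nc1nc(NCc2ccccc2)c2ncn(/C=C3/CC3(CO)CO)c2n1`, gives in this assay > 300000 nM, also a limit.
Compound 3, `CCCCOc1nc(N)nc2c1ncn2/C=C1/CC1(CO)CO`, gives in this assay > 300000 nM, again a limit.

The three measured compounds share one core and differ only in the group carried on one aromatic carbon. Compound 2 stands at the limit (the limit of > 300000 nM in this assay, at which 3 of the 3 values shown sit), the point at which every shown value sits, so where it truly lies beyond that point is unknown. The step that the two limits leave unreadable from compound 1 to compound 2 and the step that the two limits leave unreadable from compound 2 to compound 3 both exchange the group at this same position, and both are unreadable, as a limit at each end gives no size.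

Compound 4, `CC(C)Sc1nc(N)nc2c1ncn2/C=C1/CC1(CO)CO`, carries the change (isopropylsulfanyl in place of benzylamino on an aromatic carbon). The two measured exchanges at this position left the read-out at the limit, and nothing shown points to a different outcome for the isopropylsulfanyl group. The expected step is therefore a number no higher from compound 2 to compound 4 (the limit leaves the size open), none beyond the scatter. Compound 4 is expected to sit at the same limit. Compound 4 is estimated at 300000 nM, with a range from 100000 nM to 300000 nM.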

Compound 4, half-maximal cytotoxic concentration: > 300000 nM
Compound 4: a limit, no number; the forecaster's own chance of this, stated with the estimate: 85%; the middle value sits exactly at the limit.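

In this assay compound 4 gives > 300000 nM, which is a limit and not a number. No new step can be read between compound 4 and compound 1, compound 2 or compound 3, as all four compounds sit at one limit: the limit of > 300000 nM in this assay, at which 4 of the 4 values shown sit.

The compounds shown leave open how far past that limit each one truly lies, and so whether the group on this aromatic carbon affects tolerance at all.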